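Swapping the biaryl group of compound 3 for a thienylpyridine

The source may report more compounds than this note shows. Statements on the series, on what has been measured and on what is new or still open speak of the compounds shown alone.

- Compound 1 `NC1CCC(Nc2nc(NCc3ccc(-c4ccco4)cc3)c3ncn(C4CCCC4)c3n2)CC1`: 71 nM
- Compound 2 `NC1CCC(Nc2nc(NCc3ccc(-c4ccsc4)cc3)c3ncn(C4CCCC4)c3n2)CC1`: 220 nM
- Compound 3 `NC1CCC(Nc2nc(NCc3ccc(-n4cccn4)cc3)c3ncn(C4CCCC4)c3n2)CC1`: 170 nM
- Compound 4 `NC1CCC(Nc2nc(NCc3ccc(-c4ccsc4)nc3)c3ncn(C4CCCC4)c3n2)CC1`: not yet measured

In a functional assay on HeLa cells (Homo sapiens) for inhibition, with a stated time of 72 h (on this read-out higher numbers stand for weaker inhibition and lower numbers for stronger inhibition), compound 3 gives 170 nM. Against its two neighbours, the step of a 1.3-fold lower number from compound 2 to compound 3 (0.11 log units; within the scatter) stands, while the step of a 2.4-fold higher number from compound 1 to compound 3 (0.38 log units; beyond the scatter) separates it from the lowest number. The next change is 6-(thiophen-3-yl)pyridin-3-yl in place of 4-(1H-pyrazol-1-yl)phenyl on a saturated chain carbon bound to a nitrogen on an aromatic ring. The closest evidence is the step of a 1.3-fold lower number from compound 2 to compound 3 (0.11 log units; within the scatter), which suggests that exchanging these five-membered rings matters little. Among the compounds with values here, no measured compound carries the nitrogen in the six-membered ring, so that part remains untested. The expected result is a small rise, a 1.5-fold higher number from compound 3 to compound 4 (0.17 log units; within the scatter), without a clear move beyond the scatter. Compound 4 is estimated at 250 nM, with an expected range of 90 nM to 700 nM.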

Compound 4, half-maximal inhibitory concentration: 75 nM
For compound 4 the middle estimate is 3.3-fold (0.52 log units) above the measured one, outside the stated range (below it).
By their numbers in this assay, from the lowest: compounds 1 and 4 (each within the scatter of the next); then compounds 3 and 2 (each within the scatter of the next).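

In this assay, within the data shown here, the ring nitrogen is now read for the first time: with thiophen-3-yl kept, a 2.9-fold lower number from compound 2 to compound 4 (0.47 log units; beyond the scatter) shows that the six-membered ring at this position counts. The same group gives a 2.3-fold lower number from compound 3 to compound 4 (0.36 log units; beyond the scatter) against the 4-(1H-pyrazol-1-yl)phenyl group, and a 1.1-fold higher number from compound 1 to compound 4 (0.02 log units; within the scatter) leaves it within the scatter of the 4-(furan-2-yl)phenyl group. No measurement on hand explains this gain.

The compounds shown leave open whether a furan-2-yl group on the pyridine ring would add to it. They also leave open how a smaller group, such as a methoxy group or an amine, would fare in place of the thiophen-3-yl ring.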